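The source may hold more compounds than are shown below. What is called first, only, known or untested is meant among the compounds shown, and "the series" means these compounds.

In a functional assay on the whole organism for positive allosteric modulation, with Mus musculus as the target (a higher number here means that more compound is needed for the effect, a lower number that less compound is needed), two compounds sharing one core have been measured. Compound 1 `CCC(=O)N(c1ccc(Cl)c(Cl)c1)C1CCCC1O` gives 20 mg/kg, and compound 2 `CCC(=O)N(c1ccc(Cl)c(Cl)c1)C1CCCC1N(CC)CC` gives 0.3 mg/kg, the lower of these two numbers. For the measured compounds named here, the only measured step, a 67-fold lower number from compound 1 to compound 2 (1.82 log units; beyond the scatter), is large, but it replaces a hydroxy with a diethylamino and does not compare two amino groups. Compound 3 `CCCN(CCC)C1CCCC1N(C(=O)CC)c1ccc(Cl)c(Cl)c1` has dipropylamino in place of diethylamino on a saturated ring carbon. The large step therefore shows that a change at this place can matter in this assay, yet it gives no direct measure for this smaller exchange. Going by the values given here, with no measured step between two amino groups, the expected change is modest and leans towards a higher number, without clearly passing the scatter: a 1.7-fold higher number from compound 2 to compound 3 (0.22 log units; within the scatter). For compound 3 the estimated value is 0.5 mg/kg, with an expected range of 0.1 mg/kg to 2.5 mg/kg.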

Compound 3, dose for half-maximal effect: > 50 mg/kg
Compound 3 ended at the assay's limit (the forecaster's own chance of this, stated with the estimate: 5%); middle value at least 100-fold (2.00 log units) from the limit.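

In this assay, compound 3 stands at a limit of the assay and not at a number: the limit of > 50 mg/kg in this assay, at which 1 of the 3 values shown sits.

Even so, the exchange between two amino groups on this saturated ring carbon proves large, with dipropylamino in place of diethylamino giving an at least 160-fold higher number from compound 2 to compound 3 (2.22 log units; beyond the scatter). An amino group at this place is therefore not enough on its own: dipropylamino in place of hydroxy gives an at least 2.5-fold higher number from compound 1 to compound 3 (0.39 log units; beyond the scatter), whereas diethylamino in place of hydroxy gave a 67-fold lower number from compound 1 to compound 2 (1.82 log units; beyond the scatter).

On these data alone, how far the true value of compound 3 lies past the limit stays open. Also open, as far as these compounds go, is whether dimethylamino, or an amine carrying one ethyl and one propyl chain, would keep the low number of compound 2.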